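Fluoro for bromo: the same change on two cores

The compounds below may be only part of what the source reports. "The series", "measured", "known", "first", "only" and "open" are said of these compounds alone.

Compound 1 `CCCCc1nc(Cl)c(C=O)n1CCCOc1cc2c(Nc3cccc(Br)c3)ncnc2cc1OC` gives 6440 nM in a functional assay on MCF7 cells (Homo sapiens) for cytotoxicity, read by MTT assay, with a stated time of 24 h; on this read-out lower numbers stand for stronger inhibition and higher numbers for weaker inhibition. Compound 2 `CCCCc1nc(Cl)c(C=O)n1CCCOc1cc2c(Nc3cccc(F)c3)ncnc2cc1OC` carries fluoro in place of bromo on an aromatic carbon and gives 12000 nM in this assay; the step is a 1.9-fold higher number from compound 1 to compound 2 (0.27 log units; within the scatter). Compound 3 `CCCCc1nc(Cl)c(CO)n1CCCOc1cc2c(Nc3cccc(Br)c3)ncnc2cc1OC` differs from compound 1 in the core by hydroxymethyl in place of formyl on an aromatic carbon. In this assay compound 3 gives 8200 nM, a step of a 1.3-fold higher number from compound 1 to compound 3 (0.10 log units; within the scatter). Compound 4 `CCCCc1nc(Cl)c(CO)n1CCCOc1cc2c(Nc3cccc(F)c3)ncnc2cc1OC` is not yet measured; it differs from compound 3 by fluoro in place of bromo on an aromatic carbon, the same change, at the same place, as that between compound 1 and compound 2. Because a 1.9-fold higher number from compound 1 to compound 2 (0.27 log units; within the scatter) stayed within the scatter, compound 4 is expected to show a step of a 1.8-fold higher number from compound 3 to compound 4 (0.26 log units; within the scatter). The estimate for compound 4 in this assay is 15000 nM, expected to fall between 7000 nM and 35000 nM.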

Compound 4, half-maximal inhibitory concentration: 17700 nM
Estimate against measurement, compound 4: 1.2-fold (0.07 log units) below, and the stated range covers the measured number.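

In this assay, fluoro in place of bromo gives a 2.2-fold higher number from compound 3 to compound 4 (0.33 log units; beyond the scatter) on the hydroxymethyl core, and this step matches the one on the formyl core: the same change on two cores in this assay, a 1.9-fold higher number (0.27 log units; within the scatter) from compound 1 to compound 2 and a 2.2-fold higher number (0.33 log units; beyond the scatter) from compound 3 to compound 4, 1.2-fold (0.06 log units) apart, within the scatter of two such steps. Read the other way round, hydroxymethyl in place of formyl gives a 1.5-fold higher number from compound 2 to compound 4 (0.17 log units; within the scatter) with fluoro on the aromatic ring, which also matches its counterpart with bromo: the same change on two cores in this assay, a 1.3-fold higher number (0.10 log units; within the scatter) from compound 1 to compound 3 and a 1.5-fold higher number (0.17 log units; within the scatter) from compound 2 to compound 4, 1.2-fold (0.06 log units) apart, within the scatter of two such steps. Each change therefore carries between these two cores in this one cell assay, although these four compounds show neither how far that holds beyond them nor why the numbers move as they do.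

On these data alone, whether the step would hold with a carboxylic acid or an amine in place of the formyl or hydroxymethyl group remains open. So does the effect of chloro or methoxy on the same aromatic carbon.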